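Swapping a triazole for a methylpiperazine: what solubility follows

The compounds below may be only part of what the source reports. "The series", "measured", "known", "first", "only" and "open" are said of these compounds alone.

Three compounds share one core and differ only in the group on an aromatic carbon. In a physicochemical assay for solubility (a higher number here means a more soluble compound, a lower number a less soluble compound), compound 1 `O=S(=O)(Nc1nccs1)c1ccc2c(c1)OCC[C@@H]2c1ccc(C(F)(F)F)cc1N1CCNCC1` gives 288000 nM, compound 2 `O=S(=O)(Nc1nccs1)c1ccc2c(c1)OCC[C@@H]2c1ccc(C(F)(F)F)cc1-c1ccc(F)nc1` gives 21000 nM, and compound 3 `O=S(=O)(Nc1nccs1)c1ccc2c(c1)OCC[C@@H]2c1ccc(C(F)(F)F)cc1-n1ccnn1` gives 171000 nM. Compound 3 therefore stands second highest of the three, close to compound 1 and well apart from compound 2: a 1.7-fold lower number from compound 1 to compound 3 (0.23 log units; within the scatter), while an 8.1-fold higher number from compound 2 to compound 3 (0.91 log units; beyond the scatter).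

Compound 4 `CN1CCN(c2cc(C(F)(F)F)ccc2[C@H]2CCOc3cc(S(=O)(=O)Nc4nccs4)ccc32)CC1` has not yet been measured. Compared with compound 3 it shows this difference: 4-methylpiperazin-1-yl in place of 1H-1,2,3-triazol-1-yl on an aromatic carbon.

The step that bears most on this change is a 1.7-fold lower number from compound 1 to compound 3 (0.23 log units; within the scatter), since compound 1 carries a piperazin-1-yl group that resembles the 4-methylpiperazin-1-yl group entering in compound 4. That step stayed within the scatter, so reversing the triazole back to a piperazine ring is expected to move the number only a little, if at all. The estimate for compound 4 in this assay is 250000 nM, with a range from 110000 nM to 550000 nM, which would mean an expected 1.5-fold higher number from compound 3 to compound 4 (0.16 log units; within the scatter).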

Compound 4, solubility: 176000 nM
Beside the measured number, compound 4's estimate is 1.4-fold (0.15 log units) above it; the measured number falls inside the stated range.
By their numbers in this assay, from the lowest: compound 2; then compounds 3, 4 and 1 (each within the scatter of the next).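

In this assay, 4-methylpiperazin-1-yl in place of 1H-1,2,3-triazol-1-yl gives a 1.0-fold higher number from compound 3 to compound 4 (0.01 log units; within the scatter) and so leaves the number unchanged within the scatter, even though an aromatic five-membered ring gives way to a non-aromatic six-membered one. Methyl in place of hydrogen on the ring amine nitrogen gives a 1.6-fold lower number from compound 1 to compound 4 (0.21 log units; within the scatter) and is likewise a change too small to read, so this nitrogen tolerates the added methyl in this assay. With 4-methylpiperazin-1-yl in place of 6-fluoropyridin-3-yl there is an 8.4-fold higher number from compound 2 to compound 4 (0.92 log units; beyond the scatter) and thus a third compound well apart from compound 2.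

No measurement available here explains why compound 2 stands apart. Going by these compounds, whether a longer chain on the piperazine nitrogen, or a morpholine ring in its place, would keep the number in the same range remains open.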